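Working notes: from compound 3 to compound 4

This account rests on a few compounds, and the source may have more. Where it says the series, first, only, none or still open, it means among the compounds named here.

In a functional assay, read by spectrophotometry (on this read-out higher numbers stand for an effect only at larger amounts of compound and lower numbers for an effect already at smaller amounts), compound 1 (`COc1ccc(-c2cc(=O)c3ccc(OCCCN4CCC(CCO)CC4)cc3o2)cc1`) gives 22.8 nM on the shared core. Compound 2 (`COc1ccc(-c2cc(=O)c3ccc(OCCCCN4CCC(C)CC4)cc3o2)cc1`) gives 28.1 nM on the same read-out. Compound 3 (`COc1ccc(-c2cc(=O)c3ccc(OCCCCCN4CCC(CCO)CC4)cc3o2)cc1`) gives 27.9 nM and stands within the scatter of both other compounds.

Compound 4 (`COc1ccc(-c2cc(=O)c3ccc(OCCCCCCCN4CCC(C)CC4)cc3o2)cc1`) is still to be measured. The structural change is 2-(4-methylpiperidin-1-yl)ethyl in place of 4-(2-hydroxyethyl)piperidin-1-yl on a saturated chain carbon, five bonds along the chain from an oxygen on an aromatic ring and it places 2-(4-methylpiperidin-1-yl)ethyl in place of 4-(2-hydroxyethyl)piperidin-1-yl on a saturated chain carbon, five bonds along the chain from an oxygen on an aromatic ring.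

Going by the values given here, three measured steps bear on this change: a 1.2-fold higher number from compound 1 to compound 2 (0.09 log units; within the scatter) together with a 1.2-fold higher number from compound 1 to compound 3 (0.09 log units; within the scatter) and also a 1.0-fold lower number from compound 2 to compound 3 (0.00 log units; within the scatter) as the closest precedent. Each alters the chain, two of them also exchange the same piperidine ends, and none leaves the scatter. The chain of compound 4 nevertheless reaches further than that of any measured compound, so the range is kept wide.

In this assay the expected change is a 1.1-fold higher number from compound 3 to compound 4 (0.03 log units; within the scatter) and thus no step beyond the scatter. For compound 4 the estimated value is 30 nM with an expected range from 12 nM to 75 nM for the measurement.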

Compound 4, half-maximal effective concentration: 42.6 nM
Compound 4: the middle estimate sits 1.4-fold (0.15 log units) below what was measured; low and high end bracket the measured number.
By their numbers in this assay, from the lowest: compounds 1, 3, 2 and 4 (each within the scatter of the next).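

In this assay, the step on this position stays small: a 1.5-fold higher number from compound 3 to compound 4 (0.18 log units; within the scatter) accompanies 2-(4-methylpiperidin-1-yl)ethyl in place of 4-(2-hydroxyethyl)piperidin-1-yl on a saturated chain carbon, five bonds along the chain from an oxygen on an aromatic ring. With the 4-methylpiperidine end held constant, a 1.5-fold higher number from compound 2 to compound 4 (0.18 log units; within the scatter) shows that 3-(4-methylpiperidin-1-yl)propyl in place of 4-methylpiperidin-1-yl also does not separate the two compounds, and this is the first comparison to reach the longest chain shown with the same end group at both termini. Even the pair with the shortest and longest chains shown, a 1.9-fold higher number from compound 1 to compound 4 (0.27 log units; within the scatter) for 4-(4-methylpiperidin-1-yl)butyl in place of 4-(2-hydroxyethyl)piperidin-1-yl, stays inside the scatter, so no step among the four compounds on the shared core marks a clear dependence on chain or end group.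

Open, from the compounds shown here alone, is whether a longer chain ending in 4-methylpiperidine, or the chain of compound 4 ending in a carboxylic acid or a morpholine in place of the piperidine, would leave the scatter. No accompanying evidence bears on these numbers or offers an account of them.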